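This account rests on a few compounds, and the source may have more. Where it says the series, first, only, none or still open, it means among the compounds named here.

Compound 2, `COc1cc(/C=C/C(=O)c2ccncc2)cc(OC)c1OC`, gives 61 nM in an assay on cell membranes for inhibition of cytochrome P450 1A1 (Homo sapiens), read by fluorescence, using microsomes, with a stated time of 10 min (on this read-out higher numbers stand for weaker inhibition and lower numbers for stronger inhibition), the lowest of the three numbers shown. Compound 3, `CCOc1cc(/C=C/C(=O)c2ccncc2)cc(OC)c1OC`, sits next to it with 63 nM, and the step of a 1.0-fold higher number from compound 2 to compound 3 (0.01 log units; within the scatter) lies within the scatter. Compound 1, `COc1ccc(/C=C/C(=O)c2ccncc2)cc1OC`, is furthest away with 380 nM.

Compound 4, `COc1cc(/C=C/C(=O)c2ccncc2)cc(OC)c1`, is not yet measured in this assay. It differs from compound 2 by hydrogen in place of methoxy on an aromatic carbon; the group that leaves is the one para to the large group, ortho to two methoxy groups.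

Going by the values given here, no measured step removes this group. Among the compounds with values here, the steps that bear on it are those that add an alkoxy group to the ring of compound 1: a 6.2-fold lower number from compound 1 to compound 2 (0.79 log units; beyond the scatter) and a 6.0-fold lower number from compound 1 to compound 3 (0.78 log units; beyond the scatter), both modest and beyond the scatter. Those additions were at a different place, so they are only an indirect guide; still, they suggest that taking an alkoxy group away tends to raise the number. An increase of modest size is therefore expected in this assay, though a step within the scatter cannot be ruled out.

For compound 4 the estimate in this assay is 160 nM, within 50 nM to 500 nM, which is expected to mean a step of a 2.6-fold higher number from compound 2 to compound 4 (0.42 log units; beyond the scatter).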

Compound 4, half-maximal inhibitory concentration: 180 nM
Compound 4: the middle estimate sits 1.1-fold (0.05 log units) below what was measured, and the stated range covers the measured number.
By their numbers in this assay, from the lowest: compounds 2 and 3 (each within the scatter of the next); then compound 4; then compound 1.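

Going by these compounds alone, compound 4 gives the first direct reading of the methoxy group that is para to a large group and ortho to two methoxy groups: in this assay the change to hydrogen gives a 3.0-fold higher number from compound 2 to compound 4 (0.47 log units; beyond the scatter) and so shows that this group itself counts in the read-out, where the earlier steps could speak of it only indirectly. Together with a 6.2-fold lower number from compound 1 to compound 2 (0.79 log units; beyond the scatter) at another place on the ring, it shows that among these compounds the number rises when compound 2 lacks a methoxy group at either of these two places, and no compound shown goes against this. The data shown offer no measurement that explains the rise at this position.

Within the data shown here, only methoxy and hydrogen have stood at this position so far, so it stays open how a hydroxyl, an amine, a fluorine or an ethoxy group there would read. As far as these compounds go, it also stays open whether the absence of a change seen in a 1.0-fold higher number from compound 2 to compound 3 (0.01 log units; within the scatter) at another place on the ring would hold for a longer chain at this one.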